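Trifluoromethyl in place of fluoro on the aryl piperazine

The source may report more compounds than this note shows. Statements on the series, on what has been measured and on what is new or still open speak of the compounds shown alone.

Compound 1 `COCC(C(=O)N1CCN(c2cccc(C(F)(F)F)c2)CC1)N1C(=O)CCC1=O`: 25%
Compound 2 `CCC(C(=O)N1CCN(c2cccc(OC)c2)CC1)N1C(=O)CCC1=O`: 25%
Compound 3 `CCC(C(=O)N1CCN(c2cccc(F)c2)CC1)N1C(=O)CCC1=O`: 75%

Of the compounds shown here, three sharing one core have been tested in a functional assay on the whole organism (strain Swiss) with Mus musculus as the target, in the maximal electroshock model, with a stated time of 0.25 h, at a dose of 300 mg/kg by the intraperitoneal route; a lower number here means a weaker effect, a higher number a stronger effect of the compound at the dose given. Compound 3 stands highest of the three numbers. Its nearest neighbour is compound 1, which gives 25%, a gap beyond the scatter. Furthest away is compound 2, which gives 25%, the same distance below. Among the compounds with values here, the single one-place step among the measured compounds is a number 50 percentage points higher from compound 2 to compound 3 (beyond the scatter), the exchange of a methoxy group for fluoro on the aromatic carbon.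

Compound 4 `CCC(C(=O)N1CCN(c2cccc(C(F)(F)F)c2)CC1)N1C(=O)CCC1=O` is not yet measured. It differs from compound 3 in one place: trifluoromethyl in place of fluoro on an aromatic carbon. Within the data shown here, no measured step covers this exact exchange. The step from compound 2 to compound 3 shows that a change at this aromatic carbon can move this assay by a large amount, but it concerns a different pair of groups. Compound 1, which carries the trifluoromethyl group together with a different chain, gives 25%; compound 1 and compound 4 differ in the chain, so their values can only be set side by side. Taken together, a downward step of a number 25 percentage points lower from compound 3 to compound 4 (beyond the scatter) is expected, and compound 4 is estimated at 50%, within a range from 25% to 75%.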

Compound 4, a percentage reported as activity, at one dose (the size of the read-out at that dose, not a potency): 75%
Estimate against measurement, compound 4: 25 percentage points below, within the range that was stated.
By their numbers in this assay, from the lowest: compounds 1 and 2 (each within the scatter of the next); then compounds 3 and 4 (each within the scatter of the next).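

In this assay the exchange of fluoro for trifluoromethyl on the aromatic carbon, with 4 heavy atoms entering where 1 left, gives no change at the digits printed from compound 3 to compound 4 (within the scatter), so this read-out does not separate the two groups at this position. Methoxy is the group that stands apart among the three on this carbon: trifluoromethyl in its place gives a number 50 percentage points higher from compound 2 to compound 4 (beyond the scatter), a step that matches the one for fluoro in place of methoxy, a number 50 percentage points higher from compound 2 to compound 3 (beyond the scatter). On the saturated chain carbon, methyl in place of methoxy gives a number 50 percentage points higher from compound 1 to compound 4 (beyond the scatter) with trifluoromethyl held constant on the aromatic ring.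

Nothing available here accounts for any of these steps. The compounds shown leave open whether a nitrile or a chlorine atom on this aromatic carbon would group with fluoro and trifluoromethyl or with methoxy, and whether a longer chain or a hydroxyl group on the saturated chain carbon would keep the read-out of compound 4 or lower it as methoxy does in compound 1.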